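The source may report more compounds than this note shows. Statements on the series, on what has been measured and on what is new or still open speak of the compounds shown alone.

Values in an in vitro ADME assay on microsomes from liver (Homo sapiens) for metabolic stability; a lower number here means slower removal, a higher number faster removal of the compound:
- compound 1 `Cc1nnc(C2CCN(c3ccccn3)CC2)n1-c1ccccc1`: < 8 mL.min-1.g-1 (a limit of the assay)
- compound 2 `Cc1ccccc1-n1c(C)nnc1C1CCN(c2ccccn2)CC1`: 33 mL.min-1.g-1
- compound 3 `Cc1nnc(C2CCN(c3ccccn3)CC2)n1-c1ccc(Cl)cc1`: 23 mL.min-1.g-1

Going by the values given here, only two of these values are true numbers, and they lie close together: a 1.4-fold lower number from compound 2 to compound 3 (0.16 log units; within the scatter). Compound 3 therefore stands level with compound 2 within the scatter. The value of compound 1 is a limit and not a number. Measured from that limit, methyl in place of hydrogen on an aromatic carbon gives an at least 4.1-fold higher number from compound 1 to compound 2 (0.61 log units; beyond the scatter), and chloro in place of hydrogen on an aromatic carbon gives an at least 2.8-fold higher number from compound 1 to compound 3 (0.45 log units; beyond the scatter).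

The next structure is compound 4 `Cc1nnc(C2CCN(c3ccccn3)CC2)n1Cc1ccccc1`. Its difference from compound 3 is benzyl in place of 4-chlorophenyl on an aromatic nitrogen, which puts benzyl in place of 4-chlorophenyl on an aromatic nitrogen. Among the compounds with values here, no measured step makes this exact change. Within the data shown here, the closest precedent is the other exchange of a whole group on that nitrogen, a 1.4-fold lower number from compound 2 to compound 3 (0.16 log units; within the scatter), so no step beyond the scatter is expected, in either direction. The two steps from compound 1 show that the number can move with small changes to this group, so the estimated range is kept wide. The expected step, estimated to stay within the scatter, is a 1.2-fold lower number from compound 3 to compound 4 (0.06 log units; within the scatter). For compound 4 the estimated value is 20 mL.min-1.g-1, with an expected range from 9 mL.min-1.g-1 to 50 mL.min-1.g-1.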

Compound 4, intrinsic clearance in microsomes: < 8 mL.min-1.g-1
Compound 4: only a limit was reported; the forecaster's own chance of this, stated with the estimate: 12%; at least 2.5-fold (0.39 log units) between middle value and limit.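

In this assay, benzyl in place of 4-chlorophenyl gives an at least 2.8-fold lower number from compound 3 to compound 4 (0.45 log units; beyond the scatter), and benzyl in place of 2-methylphenyl gives an at least 4.1-fold lower number from compound 2 to compound 4 (0.61 log units; beyond the scatter), so exchanging the whole group on this aromatic nitrogen can move the number beyond the scatter, which the earlier exchange between the two substituted phenyl groups did not do. Compound 4 gives < 8 mL.min-1.g-1, which is a limit of the assay. Across these four compounds, phenyl and benzyl both end at a limit while the 2-methylphenyl and 4-chlorophenyl groups give true numbers, and the step between compound 1 and compound 4 cannot be read, as both of their values are limits: the limit of < 8 mL.min-1.g-1 in this assay, at which 2 of the 4 values shown sit.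

The compounds shown leave open how far the true numbers of compound 1 and compound 4 lie from that limit, and whether a methyl or chloro group on the ring of the benzyl group would raise the number as it does on phenyl. They also leave open whether a longer chain such as 2-phenylethyl, or cyclohexyl with no aromatic ring, would keep the number at the limit on this nitrogen.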